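Working notes: fluoro in place of chloro, compound 4

A few compounds are considered here, and "the series" means these few. Any claim that something is new, unique, unknown or untested is made for them only; others in the source may bear on it.

Compounds measured in a functional assay on KB cells (Homo sapiens) for inhibition, read by MTT assay, with a stated time of 24 h, tested at 100 ug/mL; on this read-out lower numbers stand for less inhibition of growth and higher numbers for more inhibition of growth at the one concentration tested:
- compound 1 `O=C(CCCCC1CCSS1)Nc1cccc(C(F)(F)F)c1`: 80%
- compound 2 `O=C(CCCCC(S)CCS)Nc1ccccc1`: 15.8%
- compound 3 `O=C(CCCCC(S)CCS)Nc1ccc(Cl)cc1`: 44.1%

Compound 3 holds the middle place of the three numbers, with compound 2 lower and compound 1 higher. Compound 1 differs from compound 3 in more than one place, so the gap between their values cannot be tied to a single change.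

The next compound is compound 4 `O=C(CCCCC(S)CCS)Nc1ccc(F)cc1`, still to be measured in this assay. The change from compound 3 is fluoro in place of chloro on an aromatic carbon, para to a large group.

Among the measured compounds shown here, only one measured step bears on this change: a number 28.3 percentage points higher from compound 2 to compound 3 (beyond the scatter). That step, chloro in place of hydrogen at the same place, is modest but beyond the scatter. For the measured compounds named here, no fluoro compound has been measured yet, so the series gives no direct reading for this group. The working expectation is that fluoro keeps part of the gain seen in a number 28.3 percentage points higher from compound 2 to compound 3 (beyond the scatter), which would place compound 4 between the two values of that step.

The estimated step is a number 14.1 percentage points lower from compound 3 to compound 4 (beyond the scatter), a modest fall that is expected to lie near the edge of the scatter. Compound 4 is estimated at 30%, with an expected range from 16% to 46%.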

Compound 4, percent growth inhibition at one concentration: 28.2%
For compound 4 the middle estimate is 1.8 percentage points above the measured one; the measured number falls inside the stated range.
By their numbers in this assay, from the lowest: compound 2; then compound 4; then compound 3; then compound 1.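

In this assay, the identity of the halogen on the aromatic carbon para to a large group matters, with a number 15.9 percentage points lower from compound 3 to compound 4 (beyond the scatter) as the step, so fluoro and chloro are not interchangeable at this place. Fluoro still improves on hydrogen, with a number 12.4 percentage points higher from compound 2 to compound 4 (beyond the scatter) on the same core, so the gain is not confined to chloro, and the three compounds with otherwise identical structures now run in the order hydrogen, fluoro, chloro, each step beyond the scatter.

Going by these compounds, whether bromo, methoxy or an amine at this place would continue that order remains open, as does the effect of either halogen elsewhere on the aromatic ring. Compound 1, at 80%, differs from the others in more than one place, so the gap to its number cannot be tied to a single change. The single concentration gives no view of the full concentration response.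

No measurement in hand explains why the two halogens differ at this place.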